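A few compounds are considered here, and "the series" means these few. Any claim that something is new, unique, unknown or untested is made for them only; others in the source may bear on it.

Measured so far:
compound 1 `Cc1cc(OC[C@@H]2CN(C)c3ccccc3O2)ccc1C(=O)n1c(C)c(CC(=O)O)c2cc(F)ccc21`, 2.7 nM
compound 2 `Cc1c(CC(=O)O)c2cc(F)ccc2n1C(=O)c1ccc(OC[C@@H]2CN(C)c3ccccc3O2)cc1Cl`, 5.2 nM

Both numbers come from an assay on CHO cells for displacement of a labelled ligand from prostaglandin D2 receptor (Mus musculus), read by scintillation counting, with a stated time of 20 min; a higher number here means a weaker inhibitor, a lower number a stronger inhibitor. Compound 1 has the lower of the two numbers, but only just: a 1.9-fold higher number from compound 1 to compound 2 (0.28 log units; within the scatter), so the two compounds cannot be told apart on this evidence. Compound 3 `Cc1cc(OC[C@@H]2COc3ccccc32)ccc1C(=O)n1c(C)c(CC(=O)O)c2cc(F)ccc21` has not been measured yet. It differs from compound 1 in one place: a group of 9 heavy atoms (8 carbon, 1 oxygen; one five-membered non-aromatic ring with 1 hetero atom, one six-membered aromatic ring of carbon only) in place of a group of 11 heavy atoms (9 carbon, 1 nitrogen, 1 oxygen; one six-membered non-aromatic ring with 2 hetero atoms, one six-membered aromatic ring of carbon only), on a saturated chain carbon bound to an oxygen on an aromatic ring. Within the data shown here, the single measured step concerns a chloro in place of a methyl on an aromatic carbon, a different part of the molecule, and offers no guide to the group swapped here. With nothing measured to lean on, the expectation rests on compound 1 alone, and a small loss that need not rise beyond the scatter is expected, a 2.2-fold higher number from compound 1 to compound 3 (0.35 log units; beyond the scatter). Compound 3 is therefore estimated at 6 nM, with a likely range from 1.5 nM to 25 nM.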

Compound 3, inhibition constant: 5.4 nM
Compound 3: the middle estimate sits 1.1-fold (0.05 log units) above what was measured; low and high end bracket the measured number.
By their numbers in this assay, from the lowest: compounds 1, 2 and 3 (each within the scatter of the next).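

Among these compounds, the first measured step concerned a chloro and a methyl on an aromatic carbon, and this is the first reading at the saturated chain carbon bound to an oxygen on an aromatic ring. In this assay, exchanging the group with the six-membered non-aromatic ring for the one with the five-membered non-aromatic ring gives a 2.0-fold higher number from compound 1 to compound 3 (0.30 log units; within the scatter), so in this pair a smaller ring group without nitrogen, with 1 hydrogen-bond acceptor in place of 2, stays in the same low-nanomolar range. No measurement here bears on why the two groups read so alike.

Ring size, the ring nitrogen and the acceptor count all change in this one step, and these compounds cannot separate them. Going by these compounds, how a plain phenyl ring or an open alkyl chain would read at this place also remains open.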